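The source may report more compounds than this note shows. Statements on the series, on what has been measured and on what is new or still open speak of the compounds shown alone.

Working notes on the series. In a functional assay on SW-620 cells (Homo sapiens) for inhibition, with a stated time of 48 h (a lower number here means a stronger inhibitor of growth, a higher number a weaker inhibitor of growth), compound 2 `C=CCc1c(O)c(C(=O)/C=C/c2ccccc2)c(OC)c2ccoc12` gives 3320 nM and compound 1 `COc1c(C(=O)/C=C/c2ccc(Cl)cc2)c(O)c(Br)c2occc12` gives 2710 nM, so the two stand level within the scatter. Compound 3 `C=CCc1c(O)c(C(=O)/C=C/c2ccc(Cl)cc2)c(OC)c2ccoc12` differs from compound 2 by chloro in place of hydrogen on an aromatic carbon, para to a large group. Among the measured compounds shown here, no measured pair isolates this change. No step beyond the scatter is expected in this assay, given that compound 1, which also carries 4-chlorophenyl, gives 2710 nM. The estimated step is a 1.2-fold lower number from compound 2 to compound 3 (0.07 log units; within the scatter). For compound 3 the expected value is 2800 nM, with an estimated range of 1300 nM to 6000 nM.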

Compound 3, concentration for 50% growth inhibition: 2560 nM
The estimate for compound 3 lay 1.1-fold (0.04 log units) above the measured number; the range from low to high includes it.
By their numbers in this assay, from the lowest: compounds 3, 1 and 2 (each within the scatter of the next).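

In this assay the phenyl to 4-chlorophenyl change now has a measured pair, with a 1.3-fold lower number from compound 2 to compound 3 (0.11 log units; within the scatter) as its step, so chloro para to a large group does not separate these two compounds. With 4-chlorophenyl held fixed, allyl in place of bromo on an aromatic carbon gives a 1.1-fold lower number from compound 1 to compound 3 (0.02 log units; within the scatter) and does not separate that pair either. Nothing at hand bears on why these steps are so small. Open, as far as these compounds go, is whether an amine or a carboxylic acid in place of chloro, or a longer chain in place of allyl, would give a step beyond the scatter.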